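The source may report more compounds than this note shows. Statements on the series, on what has been measured and on what is new or still open speak of the compounds shown alone.

In an assay on cells for displacement of a labelled ligand from metabotropic glutamate receptor 2 (Homo sapiens), read by scintillation counting, with a stated time of 60 min (on this read-out lower numbers stand for stronger inhibition and higher numbers for weaker inhibition), three close relatives of one shared core have been measured. Compound 1 `Clc1cc(-c2ccn3c(CC4CC4)nnc3c2Cl)ccc1OC1CCOCC1` gives 22.9 nM. Compound 2 `FC(F)(F)c1c(-c2ccc(OC3CCOCC3)c(Cl)c2)ccn2c(CC3CC3)nnc12` differs from compound 1 in one group, (trifluoromethyl in place of chloro on an aromatic carbon), and compound 2 gives 5.25 nM, which amounts to a 4.4-fold lower number from compound 1 to compound 2 (0.64 log units; beyond the scatter). Compound 3 `Clc1cc(-c2ccn3c(CC4CC4)nnc3c2Cl)ccc1NC1CCOCC1` differs from compound 1 elsewhere, ((oxan-4-yl)amino in place of (oxan-4-yl)oxy on an aromatic carbon), and compound 3 gives 38.9 nM; that is a 1.7-fold higher number from compound 1 to compound 3 (0.23 log units; within the scatter), so the two numbers cannot be told apart with confidence.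

Compound 4 `FC(F)(F)c1c(-c2ccc(NC3CCOCC3)c(Cl)c2)ccn2c(CC3CC3)nnc12` is not yet measured. It stands to compound 3 exactly as compound 2 stands to compound 1: the change is trifluoromethyl in place of chloro on an aromatic carbon, and the surroundings of the exchanged group are described in the same words as before, so this is the same change, now made on the core of compound 3 rather than that of compound 1. Among the compounds shown the change occurs twice, with one measured example, a 4.4-fold lower number from compound 1 to compound 2 (0.64 log units; beyond the scatter), as the only guide. Carrying that single step over, the step expected here is a 4.3-fold lower number from compound 3 to compound 4 (0.64 log units; beyond the scatter). Compound 4 is therefore expected to give about 9 nM, plausibly between 3.5 nM and 25 nM.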

Compound 4, inhibition constant: 5.01 nM
Estimate against measurement, compound 4: 1.8-fold (0.25 log units) above; the measured number falls inside the stated range.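

Putting trifluoromethyl in place of chloro on the core of compound 3 gives a 7.8-fold lower number from compound 3 to compound 4 (0.89 log units; beyond the scatter), and the two examples of this change agree: the same change on two cores in this assay, a 4.4-fold lower number (0.64 log units; beyond the scatter) from compound 1 to compound 2 and a 7.8-fold lower number (0.89 log units; beyond the scatter) from compound 3 to compound 4, 1.8-fold (0.25 log units) apart, within the scatter of two such steps The second change, (oxan-4-yl)amino in place of (oxan-4-yl)oxy, can now also be read on two cores, with a 1.0-fold lower number from compound 2 to compound 4 (0.02 log units; within the scatter) fitting the earlier step: the same change on two cores in this assay, a 1.7-fold higher number (0.23 log units; within the scatter) from compound 1 to compound 3 and a 1.0-fold lower number (0.02 log units; within the scatter) from compound 2 to compound 4, 1.8-fold (0.25 log units) apart, within the scatter of two such steps So among these four compounds each change behaves alike on both cores, which supports carrying a step from one core to the other here, but two examples per change do not show that this holds across the wider series, and they do not explain why the steps agree.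

The compounds shown leave open how a methyl or a nitrile would compare with chloro and trifluoromethyl on the same aromatic carbon. They also leave open whether the agreement would survive a longer chain in place of the oxan-4-yl group.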